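Side-chain exchange on compound 3: expected cytotoxicity

The source may hold more compounds than are shown below. What is called first, only, known or untested is meant among the compounds shown, and "the series" means these compounds.

The series is tested in a functional assay on SW480 cells (Homo sapiens) for cytotoxicity, read by MTT assay, with a stated time of 48 h; a lower number here means a stronger inhibitor, a higher number a weaker inhibitor. Compound 1 `C=CC(=C)CC[C@@H]1[C@@]2(C)CCC[C@](C)(COC(=O)/C=C\c3ccc(O)cc3)[C@@H]2CC[C@@]1(C)O` gives 13600 nM in this assay. Compound 2 `C=CC(=C)CC[C@@H]1[C@@]2(C)CCC[C@](C)(COC(=O)/C=C/c3ccc(O)cc3)[C@@H]2CC[C@@]1(C)O` gives 19300 nM. Among the compounds with values here, the step of a 1.4-fold higher number from compound 1 to compound 2 (0.15 log units; within the scatter) is the only one between two compounds with full numbers; the pair differs in drawn configuration alone (the fact that compounds 1 and 2 differ only in the configuration as drawn), and the step stays within the scatter. Compound 3 `C=C1CC[C@@H]2[C@](C)(CCC[C@]2(C)C(=O)O)[C@H]1CC/C(C)=C/CO` returns only a limit in this assay, > 40000 nM (the limit of > 40000 nM in this assay, at which 1 of the 3 values shown sits). Within the data shown here, compound 3 thus stands at the bound of the assay, while compounds 1 and 2 are the only members with numbers.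

Compound 4 `C=CC(=C)[C@H](O)C[C@H]1C(=C)CC[C@@H]2[C@]1(C)CCC[C@]2(C)C(=O)O` differs from compound 3 in one place: a group of 6 heavy atoms (5 carbon, 1 oxygen; no ring) in place of a group of 6 heavy atoms (5 carbon, 1 oxygen; no ring), on a saturated chain carbon bound to a saturated ring carbon. Among the measured compounds shown here, the measured step between compounds 1 and 2 concerns a change in configuration, not an exchange of side chain, so it gives no direct measure for this change; it shows only that a small change left the number within the scatter. For the measured compounds named here, no measured step of the kind from compound 3 to compound 4 exists. The expected step of a number no higher from compound 3 to compound 4 (the limit leaves the size open) is therefore set small, with a limit remaining the most likely outcome. Compound 4 is estimated at 40000 nM, between 15000 nM and 120000 nM.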

Compound 4, half-maximal inhibitory concentration: > 40000 nM
Compound 4: no number, only a limit (the forecaster's own chance of this, stated with the estimate: 60%); the middle value lies on the limit itself.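

Compound 3 returns only a limit, > 40000 nM. Compound 4 also returns only a limit, > 40000 nM. Within the data shown here, no step between compound 3 and compound 4 can be read from these two limits. On these data alone, whether exchanging the 4-hydroxy-2-methylbut-2-en-1-yl group for the new side chain shifts the cytotoxicity at all stays open.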